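Aryl for cyclohexyl on the aminomethyl arm

A few compounds are considered here, and "the series" means these few. Any claim that something is new, unique, unknown or untested is made for them only; others in the source may bear on it.

Measured so far in a functional assay, with a stated time of 6 min; on this read-out higher numbers stand for weaker inhibition and lower numbers for stronger inhibition:
compound 1 `S=c1[nH]nc(-c2ccc3c(c2)OCCO3)o1` gives 10600 nM
compound 2 `S=c1oc(-c2ccc3c(c2)OCCO3)nn1CNC1CCCCC1` gives 18400 nM
compound 3 `Fc1ccc(NCn2nc(-c3ccc4c(c3)OCCO4)oc2=S)cc1` gives 6480 nM

Compound 2 stands at the highest number of the three. The nearest is compound 1: a 1.7-fold higher number from compound 1 to compound 2 (0.24 log units; within the scatter), a difference within the scatter, so no order can be read between these two. The furthest is compound 3: a 2.8-fold lower number from compound 2 to compound 3 (0.45 log units; beyond the scatter), a modest step beyond the scatter.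

Compound 4 `S=c1oc(-c2ccc3c(c2)OCCO3)nn1CNc1ccc(Cl)c(Cl)c1` is not yet measured. It differs from compound 2 at the amine nitrogen: 3,4-dichlorophenyl in place of cyclohexyl on an amine nitrogen. Among the compounds with values here, the one measured step that bears on this change is the one from compound 2 to compound 3, where an aromatic ring also replaced cyclohexyl at the same amine nitrogen: a 2.8-fold lower number from compound 2 to compound 3 (0.45 log units; beyond the scatter). A step of comparable size and the same direction, towards a lower number, is therefore expected for compound 4, with no basis in the shown data for a larger one.

For compound 4 the expected value in this assay is 5500 nM, with a range from 2200 nM to 14000 nM. This estimate corresponds to a 3.3-fold lower number from compound 2 to compound 4 (0.52 log units; beyond the scatter).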

Compound 4, half-maximal inhibitory concentration: 6840 nM
For compound 4 the middle estimate is 1.2-fold (0.09 log units) below the measured one; low and high end bracket the measured number.
By their numbers in this assay, from the lowest: compounds 3, 4, 1 and 2 (each within the scatter of the next, the first and the last beyond it).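

In this assay a second aromatic ring on the amine nitrogen gives a 2.7-fold lower number from compound 2 to compound 4 (0.43 log units; beyond the scatter) in place of cyclohexyl, so the lower number is not confined to the 4-fluorophenyl of compound 3. Exchanging that group for 3,4-dichlorophenyl gives a 1.1-fold higher number from compound 3 to compound 4 (0.02 log units; within the scatter) and leaves the two aryl groups indistinguishable at this position, even with the change in halogen and the larger group. Nothing available explains either step.

Both aryl groups shown carry halogen, so the series cannot yet separate the contribution of the aromatic ring from that of its halogen substituents. Unsubstituted phenyl, a methoxyphenyl or a pyridyl on the same amine nitrogen would address that question, and a benzyl group would extend it to a longer link between nitrogen and ring.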